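The source may report more compounds than this note shows. Statements on the series, on what has been measured and on what is new or still open speak of the compounds shown alone.

- compound 1 `Cc1cnc(O)c(C(=O)Nc2cccc3cccnc23)c1`: 13.6 nM
- compound 2 `Cc1cc(Cl)cc(C(=O)Nc2cnc3ccccc3c2)c1`: 76.3 nM
- compound 3 `O=C(Nc1cnc2ccccc2c1)c1cc(Cl)cnc1Br`: 58.9 nM
- compound 4 `Cc1cc(Br)cc(C(=O)Nc2cnc3ccccc3c2)c1`: not yet measured

All numbers come from a functional assay on HUVEC cells (Homo sapiens) for inhibition, read by ELISA and BrdU incorporation; on this read-out higher numbers stand for weaker inhibition and lower numbers for stronger inhibition. Compound 2 gives 76.3 nM and stands at the upper end of the three numbers, within the scatter of compound 3 at 58.9 nM. Its number lies higher, beyond the scatter, than that of compound 1 at 13.6 nM.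

Compound 4 has bromo in place of chloro on an aromatic carbon of compound 2 (bromo in place of chloro on an aromatic carbon). That carbon belongs to a six-membered aromatic ring of carbon only and sits meta to a large group and meta to a methyl group. Among the compounds with values here, no pair of measured compounds differs in one place, so the series offers no direct precedent for this swap. The expectation therefore starts from compound 2 at 76.3 nM, with no step beyond the scatter expected in this assay and no direction favoured. The estimated change is a 1.1-fold lower number from compound 2 to compound 4 (0.04 log units; within the scatter). For compound 4 the expected value is 70 nM, with an estimated range of 30 nM to 160 nM.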

Compound 4, half-maximal inhibitory concentration: 89.6 nM
For compound 4 the middle estimate is 1.3-fold (0.11 log units) below the measured one, and the stated range covers the measured number.
By their numbers in this assay, from the lowest: compound 1; then compounds 3, 2 and 4 (each within the scatter of the next).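

In this assay, within the data shown here, this is the first pair that differs in one place, and putting bromo in place of chloro on this aromatic carbon gives a 1.2-fold higher number from compound 2 to compound 4 (0.07 log units; within the scatter), so the step stays within the scatter. At this carbon, meta to a large group and meta to a methyl group, the read-out therefore does not separate chloro from bromo, and the swap is tolerated without a measurable loss. Nothing at hand offers an explanation for this result.

Whether any group at this carbon can move the number beyond the scatter stays open, since a methoxy group or an amine there is not among the compounds shown. Also open, from the compounds shown here alone, is whether the same swap would read alike on the core of compound 1.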